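This account rests on a few compounds, and the source may have more. Where it says the series, first, only, none or still open, it means among the compounds named here.

Measured so far in a functional assay for inhibition, with Homo sapiens as the target; on this read-out higher numbers stand for weaker inhibition and lower numbers for stronger inhibition 
- compound 1 `CC(C)c1ccc2oc(NC(CC3CCCCC3)c3ccccc3)nc2c1` gives 6 nM 
- compound 2 `O=C(O)c1ccc2oc(NC(CC3CCCCC3)c3ccccc3)nc2c1` gives 150 nM 
- compound 3 `CN(C)C(=O)c1ccc2oc(NC(CC3CCCCC3)c3ccccc3)nc2c1` gives 170 nM 

Compound 3 cannot be told apart from compound 2, as the gap between them is only a 1.1-fold higher number from compound 2 to compound 3 (0.05 log units; within the scatter) and lies within the scatter. Both sit far from compound 1, which shows the strongest inhibition of the three.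

The next compound, compound 4 `N#Cc1ccc2oc(NC(CC3CCCCC3)c3ccccc3)nc2c1`, has cyano in place of dimethylcarbamoyl on an aromatic carbon and is otherwise the same molecule.

Among the compounds with values here, three measured steps bear on this change, all at the same place on the molecule. Putting carboxy in place of isopropyl gave a large step, a 25-fold higher number from compound 1 to compound 2 (1.40 log units; beyond the scatter), and putting dimethylcarbamoyl there gave a similarly large one, a 28-fold higher number from compound 1 to compound 3 (1.45 log units; beyond the scatter). Swapping carboxy for dimethylcarbamoyl gave almost nothing. So both carbonyl-bearing groups tested give much weaker inhibition than isopropyl. Cyano has no carbonyl, but no measured compound carries it, so this remains an extrapolation.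

A modest move toward stronger inhibition is therefore expected, far short of the full distance back to compound 1, with the expected step being a 2.8-fold lower number from compound 3 to compound 4 (0.45 log units; beyond the scatter) in this assay here. For compound 4 the estimated value is 60 nM, with an expected range from 15 nM to 200 nM in this estimate.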

Compound 4, half-maximal inhibitory concentration: 15 nM
Compound 4: middle estimate off by 4.0-fold (0.60 log units), on the high side; measured number inside the range.
By their numbers in this assay, from the lowest: compound 1; then compound 4; then compounds 2 and 3 (each within the scatter of the next).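

In this assay, cyano in place of dimethylcarbamoyl gives an 11-fold lower number from compound 3 to compound 4 (1.05 log units; beyond the scatter), and cyano in place of carboxy gives a 10-fold lower number from compound 2 to compound 4 (1.00 log units; beyond the scatter), so the large loss seen with those two carbonyl-bearing groups is not shared by every replacement of isopropyl at this position. Cyano does not fully match isopropyl, however, as a 2.5-fold higher number from compound 1 to compound 4 (0.40 log units; beyond the scatter) shows, so this aromatic carbon still separates the two groups, though by far less than it separates isopropyl from either carbonyl-bearing group. Dimethylcarbamoyl and cyano have the same counts of hydrogen-bond donors and acceptors, while the heavy atoms go from 5 to 2 and a double bond gives way to a triple bond, but no measurement here accounts for the size of the step.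

An acetyl group would show whether a carbonyl-bearing group with fewer heavy atoms than dimethylcarbamoyl stays close to compound 3 or moves toward compound 4. Ethyl, cyclopropyl, methoxy, chlorine or an amine at the same carbon would show how far the numbers at this position follow carbon-only groups like isopropyl and how other kinds of group compare.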